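Hydroxymethyl in place of tert-butyl on the chain carbon

A few compounds are considered here, and "the series" means these few. Any claim that something is new, unique, unknown or untested is made for them only; others in the source may bear on it.

Of the compounds shown here, two sharing one core have numbers so far. In a functional assay for inhibition, with Homo sapiens as the target (a lower number here means a stronger inhibitor, a higher number a weaker inhibitor), compound 1 (`CC(C)OC(=O)C(Cc1cccc(OCC(=O)O)c1)c1nc(-c2ccccc2)c(-c2ccccc2)o1`) gives 1220 nM and compound 2 (`CC(C)(C)C(Cc1cccc(OCC(=O)O)c1)c1nc(-c2ccccc2)c(-c2ccccc2)o1`) gives 3660 nM as the higher of the two numbers. Compound 2 therefore stands as the weaker inhibitor of the pair.

Compound 3 (`O=C(O)COc1cccc(CC(CO)c2nc(-c3ccccc3)c(-c3ccccc3)o2)c1`) differs from compound 2 at one place (hydroxymethyl in place of tert-butyl on a saturated chain carbon bound to an aromatic carbon and a saturated chain carbon), with hydroxymethyl in place of tert-butyl on a saturated chain carbon bound to an aromatic carbon and a saturated chain carbon.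

Going by the values given here, only one measured step bears on this change, since it concerns the same carbon (a 3.0-fold higher number from compound 1 to compound 2 (0.48 log units; beyond the scatter)), and it is modest. Neither measured compound carries hydroxymethyl, so that step guides the size of the change better than its direction. With tert-butyl leaving and compound 2 at the higher number, a modest move downward is expected. The expected change is a 2.2-fold lower number from compound 2 to compound 3 (0.33 log units; beyond the scatter) in this assay and remains uncertain. The estimate for compound 3 is 1700 nM within an expected range from 500 nM to 6000 nM in this assay as well.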

Compound 3, half-maximal inhibitory concentration: 9310 nM
For compound 3 the middle estimate is 5.5-fold (0.74 log units) below the measured one, and the stated range ends below it.
By their numbers in this assay, from the lowest: compound 1; then compound 2; then compound 3.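

In this assay the change from tert-butyl to hydroxymethyl gives a 2.5-fold higher number from compound 2 to compound 3 (0.41 log units; beyond the scatter) and so moves the number up, although hydroxymethyl is the smaller group by heavy atoms and, of these two, the only one with a hydrogen-bond donor. Set against isopropoxycarbonyl, the same group gives a larger step, a 7.6-fold higher number from compound 1 to compound 3 (0.88 log units; beyond the scatter), so all three groups on this saturated chain carbon now stand apart beyond the scatter, and hydroxymethyl gives the weakest inhibitor of the three. Nothing available here accounts for this order.

The three compounds leave open whether the oxygen of hydroxymethyl or its hydrogen goes with the higher number, and a methoxymethyl group on this carbon would bear on that question. They also leave open where a free carboxylic acid, an amine or a longer chain at this place would fall relative to compound 1, the lowest of the three, and whether the same order would hold on any core other than the shared one.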